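The compounds below may be only part of what the source reports. "The series", "measured", "known", "first", "only" and "open" are said of these compounds alone.

Of the compounds shown here, three have so far been tested in a functional assay on Bel-7402 cells (Homo sapiens) for inhibition, read by MTT assay, with a stated time of 24 h, tested at 100 ug/mL; a higher number here means more inhibition of growth at the concentration tested, a lower number less inhibition of growth. Compound 1 `CC(=O)SCCC(CCCCC(=O)O)SC(C)=O` gives 8.35%, compound 2 `O=C(CCCCC1CCSS1)NO` gives 12.5%, and compound 3 `O=C(CCCCC1CCSS1)Nc1ccc([N+](=O)[O-])c(C(F)(F)F)c1` gives 23.9%. Compound 2 cannot be told apart from compound 1, since the gap between them lies within the usual scatter of such measurements. Compound 3 stands clearly higher than compound 2, with a gap beyond that scatter.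

The next compound, compound 4 `O=C(CCCCC1CCSS1)Nc1ccccn1`, keeps the rest of compound 2 and alters one group. The change is pyridin-2-yl in place of hydroxy on an amide-type nitrogen. Within the data shown here, no measured pair of compounds shows this exact change, so the guide is indirect. Compound 3, at 23.9%, also has an aromatic ring on that nitrogen, though with further groups attached, and this points to an upward move rather than a downward one. With so few compounds, that hint is weak. The expected change is a number 4.5 percentage points higher from compound 2 to compound 4 (within the scatter), a small rise that would probably stay within the scatter of this assay. For compound 4 the estimated value is 17%, with an expected range from 8% to 30%.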

Compound 4, percent growth inhibition at one concentration: 37.6%
Compound 4: the middle estimate sits 20.6 percentage points below what was measured; the whole stated range lies below it.
By their numbers in this assay, from the lowest: compounds 1 and 2 (each within the scatter of the next); then compound 3; then compound 4.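

In this assay, among these compounds, the amide-type nitrogen proves to be a place where a single change moves the number: pyridin-2-yl in place of hydroxy gives a number 25.1 percentage points higher from compound 2 to compound 4 (beyond the scatter), the first one-place step that can be read. The aromatic ring on that nitrogen in compound 3 comes with further groups and gives 23.9%, while compound 4, with a pyridin-2-yl group and nothing further on the ring, gives 37.6%, so an aromatic ring at this place does not fix the number by itself. No measured property of these compounds bears on the reason for the rise.

The compounds shown leave open whether the ring nitrogen of pyridin-2-yl matters, and an unsubstituted phenyl group on the same amide-type nitrogen would test that, with pyridin-3-yl and pyridin-4-yl showing whether the location of that ring nitrogen counts. On these data alone, it also remains open how far the number depends on having a ring at all, and a simple chain such as an ethyl group at this place would speak to that.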